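A few compounds are considered here, and "the series" means these few. Any claim that something is new, unique, unknown or untested is made for them only; others in the source may bear on it.

Within the data shown here, in an in vitro ADME assay on microsomes from liver (Homo sapiens) for metabolic stability (on this read-out lower numbers stand for slow clearance and higher numbers for fast clearance), compound 2 (`CN1CC(=O)N/C1=N\C(=O)Nc1ccccn1`) gives 47 mL.min-1.g-1, the highest of the three numbers measured so far and beyond the scatter from both others: compound 1 (`CN1CC(=O)N/C1=N\C(=O)Nc1cccnc1`) gives 20 mL.min-1.g-1 and compound 3 (`CN1CC(=O)N/C1=N\C(=O)Nc1ccncc1Cl`) gives 15 mL.min-1.g-1. Compound 4 (`CN1CC(=O)N/C1=N\C(=O)Nc1ncccc1Cl`) differs from compound 2 by chloro in place of hydrogen on an aromatic carbon. Among the measured compounds shown here, no two measured compounds differ in one place only, so no direct step is available as a guide. For the measured compounds named here, the only measured compound with a chloro group, compound 3, gives 15 mL.min-1.g-1, so a modest fall is expected, about the size of the scatter. The expected change is a 1.7-fold lower number from compound 2 to compound 4 (0.22 log units; within the scatter). For compound 4 the estimated value is 28 mL.min-1.g-1, with an expected range from 12 mL.min-1.g-1 to 60 mL.min-1.g-1.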

Compound 4, intrinsic clearance in microsomes: 42 mL.min-1.g-1
Compound 4: the middle estimate sits 1.5-fold (0.18 log units) below what was measured, within the range that was stated.
By their numbers in this assay, from the lowest: compounds 3 and 1 (each within the scatter of the next); then compounds 4 and 2 (each within the scatter of the next).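

In this assay, chloro in place of hydrogen on an aromatic carbon, two atoms from the ring nitrogen and ortho to a large group, comes with a 1.1-fold lower number from compound 2 to compound 4 (0.05 log units; within the scatter). Among these compounds, this is the first comparison of two compounds that differ in one place only, and it puts compound 2 and compound 4 within the usual scatter of each other. Among the compounds shown here, at this position, the chloro group therefore gives no measurable step on this read-out.

As far as these compounds go, whether an amine or a methoxy group at the same position would behave like chloro remains open. No measurement shown explains this result.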